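Trifluoromethyl on the benzoyl ring of compound 3

A few compounds are considered here, and "the series" means these few. Any claim that something is new, unique, unknown or untested is made for them only; others in the source may bear on it.

Compound 3 `O=C(c1ccccc1)N(/N=N/c1ccc([N+](=O)[O-])cc1C(F)(F)F)c1ccc([N+](=O)[O-])cc1C(F)(F)F` gives 600 nM in a functional assay on HeLa cells (Homo sapiens) for cytotoxicity, read by MTT assay, with a stated time of 72 h; on this read-out lower numbers stand for stronger inhibition and higher numbers for weaker inhibition. Among the three measured compounds it carries the second highest number. Compound 2 `O=C(c1ccccc1)N(/N=N/c1ccc([N+](=O)[O-])cc1Cl)c1ccc([N+](=O)[O-])cc1Cl` gives 590 nM in this assay, and the two values lie within the scatter of each other. Compound 1 `O=C(c1ccccc1C(F)(F)F)N(/N=N/c1ccc([N+](=O)[O-])cc1Br)c1ccc([N+](=O)[O-])cc1Br` gives 13300 nM in this assay, a number beyond the scatter above that of compound 3. For the measured compounds named here, no two measured compounds differ in one place only, so no single change can be read off directly from the measured set.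

Compound 4 `O=C(c1ccccc1C(F)(F)F)N(/N=N/c1ccc([N+](=O)[O-])cc1C(F)(F)F)c1ccc([N+](=O)[O-])cc1C(F)(F)F` has not yet been measured in this assay. Against compound 3 the difference is trifluoromethyl in place of hydrogen on an aromatic carbon, which turns the benzoyl group into a (2-(trifluoromethyl)phenyl)carbonyl group.

Going by the values given here, the only measured compound that carries this benzoyl substituent is compound 1, and its number, 13300 nM, stands well above those of compound 2 and compound 3, though compound 1 also differs in the groups on the other two rings. On that basis a step upward beyond the scatter is expected, an 8.3-fold higher number from compound 3 to compound 4 (0.92 log units; beyond the scatter), though with wide uncertainty. Compound 4 is expected to give about 5000 nM in this assay, with a likely range from 1000 nM to 25000 nM.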

Compound 4, half-maximal inhibitory concentration: 5350 nM
Compound 4: middle estimate off by 1.1-fold (0.03 log units), on the low side, and the stated range covers the measured number.
By their numbers in this assay, from the lowest: compounds 2 and 3 (each within the scatter of the next); then compound 4; then compound 1.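

In this assay, for the compounds shown here, the pair of compound 3 and compound 4 gives the first direct reading of a single change: trifluoromethyl in place of hydrogen on an aromatic carbon of the benzoyl ring, ortho to a large group, produces an 8.9-fold higher number from compound 3 to compound 4 (0.95 log units; beyond the scatter). As the rest of the structure is identical in this pair, the higher number, which stands for weaker inhibition, can be assigned to this one substitution, and the benzoyl ring is shown to be sensitive to change at this carbon. No measured property of these compounds bears on the step, so the data offer no account of its origin.

The compounds shown leave open whether other groups at this carbon, such as fluorine, methyl, methoxy, an amine or a carboxylic acid, would shift the number to a similar extent, or whether trifluoromethyl at another carbon of the benzoyl ring would do the same. Also open, from the compounds shown here alone, is whether the step carries over to the core of compound 2, which has chlorine on the two outer rings.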